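A few compounds are considered here, and "the series" means these few. Any claim that something is new, unique, unknown or untested is made for them only; others in the source may bear on it.

Compound 1, `Nc1sc2c(c1C(=O)c1cccc3ccccc13)CCCC2`: in an assay on isolated protein with adenosine receptor A1 (Homo sapiens) as the target, tested at 10 uM (on this read-out lower numbers stand for less inhibition and higher numbers for more inhibition at the one concentration tested (going by the name of the read-out)), compound 1 gives 2%.
Compound 2, `Nc1sc2c(c1C(=O)c1ccc(Cl)c3ccccc13)CCCC2`: compound 2 gives 4.8%.
Compound 3, `Nc1sc2c(c1C(=O)c1ccc(Br)c3ccccc13)CCCC2`: compound 3 gives 12%.

Among these three numbers compound 3 shows the highest, yet its lead is small: the difference is a number 7.2 percentage points higher from compound 2 to compound 3 (within the scatter) and a number 10 percentage points higher from compound 1 to compound 3 (within the scatter), both of a size that repeated measurements of the same compound could produce, so the three compounds cannot be ranked against one another.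

The next compound is compound 4, `Nc1sc2c(c1C(=O)c1ccc(I)c3ccccc13)CCCC2`. Compared with compound 3 the change is iodo in place of bromo on an aromatic carbon. Among the measured compounds shown here, the steps that bear on this are the earlier swaps at the same aromatic carbon: a number 2.8 percentage points higher from compound 1 to compound 2 (within the scatter), a number 10 percentage points higher from compound 1 to compound 3 (within the scatter) and a number 7.2 percentage points higher from compound 2 to compound 3 (within the scatter). Each moved the number upward by a little, but none beyond the scatter. A further swap of one halogen for another is therefore expected to give no step beyond the scatter in this assay, with at most a slight upward drift: the estimated step is a number 3 percentage points higher from compound 3 to compound 4 (within the scatter). Compound 4 is thus estimated at 15%, with a range from 3% to 30%.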

Compound 4, a percentage reported as inhibition, at one concentration (the size of the read-out at that concentration, not a potency): 15.3%
Estimate against measurement, compound 4: 0.3 percentage points below, within the range that was stated.
By their numbers in this assay, from the lowest: compounds 1, 2, 3 and 4 (each within the scatter of the next, the first and the last beyond it).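

In this assay, among the compounds shown here, iodo is the first halogen at this place, para to a large group, to move the number beyond the scatter, with a number 13.3 percentage points higher from compound 1 to compound 4 (beyond the scatter) against hydrogen and a number 10.5 percentage points higher from compound 2 to compound 4 (beyond the scatter) against chloro, though both steps are modest. The swap from bromo gives only a number 3.3 percentage points higher from compound 3 to compound 4 (within the scatter) and so leaves iodo and bromo impossible to tell apart at this position. Nothing measured alongside these numbers offers a reason for these steps.

The compounds shown leave open whether a group other than a halogen at this place, such as an amine, a methoxy group or a carboxylic acid, would shift the number at all. They also leave open whether a longer chain here would go beyond what iodo gives.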